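Demethylation of the amine side chain: compound 1 to compound 3

The source may hold more compounds than are shown below. What is called first, only, known or untested is meant among the compounds shown, and "the series" means these compounds.

Measured compounds:
compound 1 `COc1ccc(Cc2nc(-c3cc(Br)c(OCCCN(C)C)c(Br)c3)c[nH]c2=O)cc1Br` — 29600 nM
compound 2 `COc1ccc(Cc2nc(-c3cc(Br)c(OCCCN(C)C)c(Br)c3)cnc2Cl)cc1Br` — "not determined" (no result reported)

The study rests on a single number. Within the data shown here, in a functional assay on B16-F10 cells (Mus musculus) for inhibition, read by MTT assay, with a stated time of 24 h (on this read-out lower numbers stand for stronger inhibition and higher numbers for weaker inhibition), compound 1 gives 29600 nM, which is the only value shown; in this assay compound 2 gives "not determined" (no result reported), so nothing can be said of its position relative to compound 1. Compound 1 therefore stands alone, a weak inhibitor by its own number, with nothing to rank it against.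

Compound 3 `CNCCCOc1c(Br)cc(-c2c[nH]c(=O)c(Cc3ccc(OC)c(Br)c3)n2)cc1Br` has not yet been measured in this assay. It differs from compound 1 in one place (hydrogen in place of methyl on an amine nitrogen); the amine that carried two methyl groups now carries one. Among the measured compounds shown here, no step between measured compounds is available to calibrate a change of this kind, so the expectation can lean only on compound 1 and the smallness of the change. The step of a 1.0-fold higher number from compound 1 to compound 3 (0.01 log units; within the scatter) is expected to be small, in no set direction, and not beyond the usual scatter. Compound 3 is accordingly estimated to give 30000 nM, within 10000 nM to 90000 nM.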

Compound 3, half-maximal inhibitory concentration: 42800 nM
For compound 3 the middle estimate is 1.4-fold (0.15 log units) below the measured one; measured number inside the range.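

In this assay, among these compounds, the step of a 1.4-fold higher number from compound 1 to compound 3 (0.16 log units; within the scatter) is the first change that can be read between two measured compounds, and it lies within the usual scatter of repeated measurements. Among the compounds shown here, the two compounds therefore cannot be told apart on this read-out, and at this amine nitrogen, whose other neighbours are saturated chain carbons, hydrogen in place of methyl leaves no effect that this pair can resolve. That holds for this one pair on the shared core, a dimethylamino end set against a methylamino end, and no accompanying evidence bears on why the two read alike.

As far as these compounds go, what remains open is how far this tolerance extends, since a single small step says nothing about larger changes at the same nitrogen. The compounds shown do not tell how a primary amine, with both methyl groups gone, a diethylamino group, a carboxylic acid in place of the amine, or a longer chain would read against compound 1 in this assay and its single number.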